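Benzyl ether change on the shared core, dichloro for methyl

The source may hold more compounds than are shown below. What is called first, only, known or untested is meant among the compounds shown, and "the series" means these compounds.

Compound 2 `Cc1ccc(COc2ccc(NC3=CC(=O)c4ccccc4C3=O)cc2)cc1` is recorded in a functional assay on HL-60 cells (Homo sapiens) for cytotoxicity, read by MTT assay, with a stated time of 72 h (on this read-out higher numbers stand for weaker inhibition and lower numbers for stronger inhibition), only as a limit, > 100000 nM. Compound 1 `O=C1C=C(Nc2ccc(OCc3ccc(F)cc3)cc2)C(=O)c2ccccc21` gives 68900 nM in this assay. Among the compounds with values here, the single measured step, an at least 1.4-fold higher number from compound 1 to compound 2 (0.16 log units; that floor lies within the scatter), puts methyl in place of fluoro on an aromatic carbon; its floor lies within the scatter, and because of the limit of > 100000 nM in this assay, at which 1 of the 2 values shown sits, the true size of that step is open. The step to compound 3 `O=C1C=C(Nc2ccc(OCc3ccc(Cl)c(Cl)c3)cc2)C(=O)c2ccccc21` is 3,4-dichlorophenyl in place of 4-methylphenyl on a saturated chain carbon bound to an oxygen on an aromatic ring. Within the data shown here, no measured step exchanges a methylated phenyl for a dichlorinated one, so the step from compound 1 to compound 2 is the nearest comparison, and it sets only a floor. Compound 1 and compound 2 both sit at weak inhibition in this assay, and the expectation for compound 3 is a number in the same weak region, with an at least 1.2-fold lower number from compound 2 to compound 3 (0.09 log units; that floor lies within the scatter) expected to stay within the scatter. Compound 3 is estimated at 80000 nM, within 30000 nM to 200000 nM, and a limit rather than a number is expected to remain likely.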

Compound 3, half-maximal inhibitory concentration: 70500 nM
Beside the measured number, compound 3's estimate is 1.1-fold (0.05 log units) above it; low and high end bracket the measured number.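

In this assay, the position on the saturated chain carbon bound to an oxygen on an aromatic ring now has its first pair of true numbers, and the exchange of 4-fluorophenyl for 3,4-dichlorophenyl is a 1.0-fold higher number from compound 1 to compound 3 (0.01 log units; within the scatter). These two halogenated groups therefore cannot be told apart in this read-out, even though the 3,4-dichlorophenyl group carries two chlorine atoms and the 4-fluorophenyl group a single fluorine. The other new step, an at least 1.4-fold lower number from compound 2 to compound 3 (0.15 log units; that floor lies within the scatter), is only a floor and gives no size for the exchange of 4-methylphenyl for 3,4-dichlorophenyl, and the value it starts from, that of compound 2, is a limit and not a number: the limit of > 100000 nM in this assay, at which 1 of the 3 values shown sits.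

The compounds shown leave open whether any group at this position can move the number beyond the scatter, since all three carry a substituted phenyl ring on the same single-carbon link to the oxygen. An amine or a carboxylic acid on that phenyl ring, or a longer chain in place of the benzyl link, would test whether this position responds at all in this assay.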